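A few compounds are considered here, and "the series" means these few. Any claim that something is new, unique, unknown or untested is made for them only; others in the source may bear on it.

Measured so far in an in vitro assay on HEK-tsA201 cells for antagonist activity at Neuronal acetylcholine receptor; alpha4/beta2 (Homo sapiens), read by fluorescence and calcium flux; on this read-out lower numbers stand for stronger inhibition and higher numbers for weaker inhibition:
Compound 1 `CCCOc1ccc(C(=O)Nc2cccc(Nc3ccccc3)n2)cc1` gives > 100000 nM, which is a limit of the assay rather than a number.
Compound 2 `CCCOc1ccc(C(=O)Nc2cccc(Nc3ccc(Cl)cc3)n2)cc1` gives > 100000 nM, again a limit of the assay rather than a number.

Compound 2 therefore stands at the limit in this assay, and nothing more can be read from its value. Within the data shown here, the one measured step, a step that the two limits leave unreadable from compound 1 to compound 2, is unreadable for the same reason: both ends sit at the limit of > 100000 nM in this assay, at which 2 of the 2 values shown sit.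

Compound 3 `CCCOc1ccc(C(=O)Nc2cccc(NCc3ccccc3)n2)cc1` differs from compound 2 in one place: benzyl in place of 4-chlorophenyl on a nitrogen on an aromatic ring. Among the measured compounds shown here, no measured step involves a benzyl group, so no direction or size can be read for this change from the data at hand. With both measured values at the limit, the expectation for compound 3 is simply that it stays there as well, and the step that the limit leaves unreadable from compound 2 to compound 3 is expected to be no real change. Compound 3 is therefore estimated at 150000 nM, with a likely range from 30000 nM to 1000000 nM.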

Compound 3, half-maximal inhibitory concentration: > 100000 nM
Compound 3: no number, only a limit; the forecaster's own chance of this, stated with the estimate: 85%; the middle value lies beyond the limit too.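

No step among compound 1, compound 2 and compound 3 can be read in this assay, because each gives only a limit of the assay rather than a number: the limit of > 100000 nM in this assay, at which 3 of the 3 values shown sit.

Still open, as far as these compounds go, is whether phenyl, 4-chlorophenyl and benzyl on the shared core differ at all in inhibition, and what change would give a measurable value.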